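The source may report more compounds than this note shows. Statements on the series, on what has been measured and on what is new or still open speak of the compounds shown alone.

Measured in a functional assay on SW-620 cells (Homo sapiens) for inhibition; a higher number here means a weaker inhibitor, a lower number a stronger inhibitor:
compound 1 `CC(=O)OC(C)n1cnc2c(S)nc(F)nc21` gives > 500000 nM, a limit of this assay.
compound 2 `CC(=O)OCCOn1cnc2c(S)nc(F)nc21` gives > 500000 nM, a limit of this assay.
compound 3 `CC(O)n1cnc2c(S)nc(F)nc21` gives > 500000 nM, a limit of this assay.

Compound 3 therefore has no number in this assay, only a limit; every measured member of the series sits at the limit of > 500000 nM in this assay, at which 3 of the 3 values shown sit, and compound 3 is not separable from the others on the figures. Going by the values given here, the one measured step, a step that the two limits leave unreadable from compound 1 to compound 3, cannot be read because both of its ends sit at the limit of > 500000 nM in this assay, at which 3 of the 3 values shown sit, so it gives no size and no direction.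

Compound 4 `OCCOn1cnc2c(S)nc(F)nc21` differs from compound 3 by 2-hydroxyethoxy in place of 1-hydroxyethyl on an aromatic nitrogen. Among the compounds with values here, no measured step bears on this change: the only step in hand is unreadable, and compound 2, which carries the acetylated form of the same 2-hydroxyethoxy chain, gives only a limit of this assay. With no readable movement anywhere in the series, compound 4 is expected to remain at the limit as well, the step that the limit leaves unreadable from compound 3 to compound 4 being estimated as none beyond the scatter. The estimate for compound 4 is 600000 nM, range 150000 nM to 2000000 nM, most likely reported as a limit only.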

Compound 4, half-maximal inhibitory concentration: > 500000 nM
Compound 4 gave a limit, no number; the forecaster's own chance of this, stated with the estimate: 85%; the middle value is on the limit's open side.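

Compound 4 adds no readable step: its steps from compound 2 and from compound 3 both join limits, not numbers, and cannot be read: the limit of > 500000 nM in this assay, at which 4 of the 4 values shown sit.

The compounds shown leave open which change to the shared core, if any, would give a measurable value in this assay.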